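This account rests on a few compounds, and the source may have more. Where it says the series, first, only, none or still open, it means among the compounds named here.

Compound 1 `CN(C)C(=O)c1cc2cnc(Nc3ccc(C(=O)NCCCCCN=C=S)cc3)nc2n1C1CCCC1`, compound 2 `CN(C)C(=O)c1cc2cnc(Nc3ccc(C(=O)NCCCCCCN=C=S)cc3)nc2n1C1CCCC1` and compound 3 `CN(C)C(=O)c1cc2cnc(Nc3ccc(NC(=O)CCCCCN=C=S)cc3)nc2n1C1CCCC1` share one core and differ only in a chain that ends in an isothiocyanate group. In a functional assay on NCI-H1299 cells (Homo sapiens) for inhibition, read by CCK-8 assay, with a stated time of 72 h, tested at 10 uM (on this read-out higher numbers stand for a stronger effect at the one concentration tested and lower numbers for a weaker effect), compound 1 gives 76.5%, compound 2 gives 85% and compound 3 gives 85%. Lengthening the chain by one carbon, (a group of 4 heavy atoms (2 carbon, 1 nitrogen, 1 sulfur; no ring) in place of a group of 3 heavy atoms (1 carbon, 1 nitrogen, 1 sulfur; no ring), on a saturated chain carbon, five bonds along the chain from an amide-type nitrogen), gave a number 8.5 percentage points higher from compound 1 to compound 2 (within the scatter). The cores of compound 1 and compound 3 differ in how the same atoms are joined, (a group of 11 heavy atoms (7 carbon, 2 nitrogen, 1 oxygen, 1 sulfur; no ring) in place of a group of 11 heavy atoms (7 carbon, 2 nitrogen, 1 oxygen, 1 sulfur; no ring), on an aromatic carbon), and that change gave a number 8.5 percentage points higher from compound 1 to compound 3 (within the scatter).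

Compound 4 `CN(C)C(=O)c1cc2cnc(Nc3ccc(NC(=O)CCCCCCN=C=S)cc3)nc2n1C1CCCC1` is the unmeasured partner of compound 3, made from it by a group of 4 heavy atoms (2 carbon, 1 nitrogen, 1 sulfur; no ring) in place of a group of 3 heavy atoms (1 carbon, 1 nitrogen, 1 sulfur; no ring), on a saturated chain carbon, five bonds along the chain from a carbonyl carbon. Within the data shown here, this is the same kind of change as the one from compound 1 to compound 2, though not the same: there the place was five bonds along the chain from an amide-type nitrogen, here it is five bonds along the chain from a carbonyl carbon. Because a number 8.5 percentage points higher from compound 1 to compound 2 (within the scatter) stayed within the scatter, the step from compound 3 to compound 4 in this assay is expected to be about a number 1 percentage points higher from compound 3 to compound 4 (within the scatter). Compound 4 is therefore estimated at 86%, most likely between 76% and 94%.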

Compound 4, a percentage reported as inhibition, at one concentration (the size of the read-out at that concentration, not a potency): 80.9%
Estimate against measurement, compound 4: 5.1 percentage points above, within the range that was stated.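

In this assay, adding one carbon to the chain on the second core gave a number 4.1 percentage points lower from compound 3 to compound 4 (within the scatter), and the two comparisons that also change the core gave a number 4.1 percentage points lower from compound 2 to compound 4 (within the scatter) and a number 4.4 percentage points higher from compound 1 to compound 4 (within the scatter). Set beside the earlier step, the same one-carbon lengthening gives two results that cannot be told apart: the same change on two cores in this assay, a number 8.5 percentage points higher (within the scatter) from compound 1 to compound 2 and a number 4.1 percentage points lower (within the scatter) from compound 3 to compound 4, 12.6 percentage points apart, within the scatter of two such steps So on both cores the extra carbon leaves the read-out within the usual scatter, but this does not show that the change carries over unchanged, as neither step is large enough to give a clear direction and only two cores are compared.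

The compounds shown leave open what a shorter or a much longer chain would do, and what an amine or a carboxylic acid would do in place of the isothiocyanate group at the chain end. Each read-out comes from a single concentration, and it tells only of a stronger or weaker effect at that concentration.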